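Swapping an alkyl for a methoxybenzyl on the ring nitrogen

The source may report more compounds than this note shows. Statements on the series, on what has been measured and on what is new or still open speak of the compounds shown alone.

Of the compounds shown here, three built on a shared core have been measured in an assay on Prostate gland for inhibition of steroid 5-alpha-reductase (Rattus norvegicus); a higher number here means a weaker inhibitor, a lower number a stronger inhibitor. Compound 2 `CCCC(C)n1ccc2cc(/C(C)=C/C(=O)Nc3ccccc3OCCCC(=O)O)ccc21` gives 7.8 nM, the lowest of the three numbers. Compound 3 `C/C(=C\C(=O)Nc1ccccc1OCCCC(=O)O)c1ccc2c(ccn2Cc2ccccc2C)c1` gives 69 nM, and compound 1 `CC(C)=CCn1ccc2cc(/C(C)=C/C(=O)Nc3ccccc3OCCCC(=O)O)ccc21` gives 120 nM. The steps of an 8.8-fold higher number from compound 2 to compound 3 (0.95 log units; beyond the scatter) and a 15-fold lower number from compound 1 to compound 2 (1.19 log units; beyond the scatter) lie beyond the scatter, while a 1.7-fold lower number from compound 1 to compound 3 (0.24 log units; within the scatter) does not.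

Compound 4 `COc1ccc(Cn2ccc3cc(/C(C)=C/C(=O)Nc4ccccc4OCCCC(=O)O)ccc32)cc1` differs from compound 2 in one place: 4-methoxybenzyl in place of 1-methylbutyl on an aromatic nitrogen. The measured step that bears most on this change is an 8.8-fold higher number from compound 2 to compound 3 (0.95 log units; beyond the scatter), where another benzyl group replaced the same 1-methylbutyl on the same aromatic nitrogen and the number rose by a modest amount. For the measured compounds named here, no measured pair shows what a methoxy substituent on such a benzyl group does, so that part of the change remains unknown. Compound 4 is therefore expected to show a step of similar size and direction, namely a 7.7-fold higher number from compound 2 to compound 4 (0.89 log units; beyond the scatter). Compound 4 is estimated at 60 nM in this assay, with a range from 20 nM to 200 nM.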

Compound 4, half-maximal inhibitory concentration: 480 nM
Compound 4: the middle estimate sits 8.0-fold (0.90 log units) below what was measured; measured number outside the range, above it.
By their numbers in this assay, from the lowest: compound 2; then compounds 3 and 1 (each within the scatter of the next); then compound 4.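

In this assay the aromatic nitrogen turns out to be far less forgiving of a benzyl group than compound 3 suggested: the step of a 62-fold higher number from compound 2 to compound 4 (1.79 log units; beyond the scatter) is much larger than the step of an 8.8-fold higher number from compound 2 to compound 3 (0.95 log units; beyond the scatter). The two benzyl groups are not interchangeable here, as the step of a 7.0-fold higher number from compound 3 to compound 4 (0.84 log units; beyond the scatter) shows, and the step of a 4.0-fold higher number from compound 1 to compound 4 (0.60 log units; beyond the scatter) makes compound 4 the weakest of the four, beyond the scatter from each of the others. Nothing available accounts for this loss.

The compounds shown leave open whether the loss belongs to the methoxy group itself or to the place it occupies on the benzyl group. An unsubstituted benzyl, a 2-methoxybenzyl or a 4-methylbenzyl on the same nitrogen would separate these readings.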